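The source may hold more compounds than are shown below. What is called first, only, known or untested is meant among the compounds shown, and "the series" means these compounds.

Compound 1 `CCc1ccccc1N(Cc1nnc(Cc2ccccc2)o1)S(=O)(=O)c1ccc(C)cc1` is the anchor of this small set. In an assay on CHO cells for displacement of a labelled ligand from prostaglandin E2 receptor EP1 subtype (Homo sapiens) (a higher number here means a weaker inhibitor, a lower number a stronger inhibitor), compound 1 gives 1000 nM. Compound 2 `CCc1ccccc1N(Cc1nnc(Oc2ccc(OC)cc2)o1)S(=O)(=O)c1ccc(C)cc1` carries 4-methoxyphenoxy where compound 1 carries benzyl. In this assay compound 2 gives < 1000 nM, which is a limit of the assay rather than a number (the limit of < 1000 nM in this assay, at which 1 of the 2 values shown sits). The step of a number no higher from compound 1 to compound 2 (the limit leaves the size open) therefore has a direction but no readable size, and compound 2 stands at that limit rather than at a known point. Compound 3 `CCc1ccccc1N(Cc1nnc(CNc2ccc(OC)cc2)o1)S(=O)(=O)c1ccc(C)cc1` has not yet been measured. It differs from compound 2 in one place: ((4-methoxyphenyl)amino)methyl in place of 4-methoxyphenoxy on an aromatic carbon. For the measured compounds named here, no measured step covers this exchange, so the only guide is that compound 2 sits at the limit. The step that the limit leaves unreadable from compound 2 to compound 3 is expected to lie within the usual scatter. Compound 3 is therefore estimated at 600 nM in this assay, with a range from 100 nM to 3000 nM.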

Compound 3, half-maximal inhibitory concentration: 501 nM
Compound 3: middle estimate off by 1.2-fold (0.08 log units), on the high side; the range from low to high includes it.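

In this assay, the position on the five-membered aromatic ring now has a second readable group, and the step is a 2.0-fold lower number from compound 1 to compound 3 (0.30 log units; within the scatter). This exchange of phenyl for (4-methoxyphenyl)amino on the saturated chain carbon therefore brings in the hydrogen-bond donor of ((4-methoxyphenyl)amino)methyl and a methoxy group, yet compound 1 and compound 3 stay within the scatter of each other. The steps that touch compound 2 cannot be read, because its value is a limit of the assay and not a number: the limit of < 1000 nM in this assay, at which 1 of the 3 values shown sits.

The compounds shown do not separate the amino nitrogen from the methoxy group, since both enter in the same step. They also leave open how this position would respond to a carboxylic acid or a longer chain.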